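Dimethyl Substitution on the Acetylpiperazine of a Substance-P Antagonist

The compounds below may be only part of what the source reports. "The series", "measured", "known", "first", "only" and "open" are said of these compounds alone.

The series begins with compound 1 `CC(=O)N1C(C)CN(c2nc3c(c(-c4ccccc4C)n2)C(=O)N(Cc2cc(C(F)(F)F)cc(C(F)(F)F)c2)C[C@@H](C)CO3)CC1C`, which in a functional assay on ileum for antagonist activity at Substance-P receptor (Cavia porcellus) (a higher number here means a weaker inhibitor, a lower number a stronger inhibitor), gives 52.9 nM. Compound 2 `CC(=O)N1CCN(c2nc3c(c(-c4ccccc4C)n2)C(=O)N(Cc2cc(C(F)(F)F)cc(C(F)(F)F)c2)C[C@H](C)CO3)CC1` stands at the low end of the two numbers recorded so far: in this assay compound 2 gives 0.139 nM, and the nearest neighbour, compound 1, sits at a markedly higher number, a gap well beyond the scatter of the method.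

The step under consideration leads from compound 2 to compound 3 `CC(=O)N1C(C)CN(c2nc3c(c(-c4ccccc4C)n2)C(=O)N(Cc2cc(C(F)(F)F)cc(C(F)(F)F)c2)C[C@H](C)CO3)CC1C`, in which (a group of 11 heavy atoms (8 carbon, 2 nitrogen, 1 oxygen; one six-membered non-aromatic ring with 2 hetero atoms) in place of a group of 9 heavy atoms (6 carbon, 2 nitrogen, 1 oxygen; one six-membered non-aromatic ring with 2 hetero atoms), on an aromatic carbon). Among the compounds with values here, no measured pair in the set isolates this change on its own, so no directly comparable step is available from the data at hand.

Given that compound 2 reaches 0.139 nM, the author expects compound 3 to remain a strong inhibitor in this assay, with the added methyl groups producing at most a modest shift and most likely a step toward a somewhat higher number, a 2.9-fold higher number from compound 2 to compound 3 (0.46 log units; beyond the scatter). Compound 3 is therefore estimated at 0.4 nM, with a plausible range from 0.08 nM to 3 nM.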

Compound 3, antagonist equilibrium constant: 0.217 nM
Compound 3: middle estimate off by 1.8-fold (0.27 log units), on the high side; the range from low to high includes it.
By their numbers in this assay, from the lowest: compounds 2 and 3 (each within the scatter of the next); then compound 1.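

Adding two methyl groups to the 4-acetylpiperazin-1-yl group, at this place on the aromatic carbon, leaves the number in this assay within the scatter, with a 1.6-fold higher number from compound 2 to compound 3 (0.19 log units; within the scatter). The substituted ring therefore fits here as well as the unsubstituted one, at least with the stereocentre drawn S, and this could not be read from the earlier pair, which differed in more than one place. A single stereocentre at a saturated ring carbon, drawn R on one side and S on the other, accounts for a far larger difference, a 240-fold lower number from compound 1 to compound 3 (2.39 log units; beyond the scatter), and the ground for placing the gap at this stereocentre rather than at the methyl groups is this: the fact that one of compounds 1 and 3 is drawn with a defined configuration and the other without, at the place where they differ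

The compounds shown leave open how the unsubstituted 4-acetylpiperazin-1-yl group behaves with the stereocentre drawn R, and so whether the methyl groups contribute anything in that series. They also leave open whether the ring tolerates a single methyl group, ethyl groups in place of the methyl groups, or a propanoyl group or a free amine in place of the acetyl group.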